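Methoxyphenyl in Place of Dichlorophenyl on the Carbonyl

The source may hold more compounds than are shown below. What is called first, only, known or untested is meant among the compounds shown, and "the series" means these compounds.

Compound 2 `COc1cc(-c2cc(/C=C/C(=O)c3ccc(Cl)c(Cl)c3)[nH]n2)cc(OC)c1OC` gives 40% in a functional assay on UO-31 cells (Homo sapiens) for cytotoxicity, read by sulforhodamine B assay, with a stated time of 48 h, tested at 10 uM (on this read-out higher numbers stand for a weaker effect at the one concentration tested and lower numbers for a stronger effect), the highest of the three numbers measured. Compound 1 `COc1cc(-c2cc(/C=C/C(=O)c3ccc(N)cc3)[nH]n2)cc(OC)c1OC` gives -84% in this assay, and compound 3 `COc1ccc(-c2cc(/C=C/C(=O)c3cc(OC)c(OC)c(OC)c3)[nH]n2)cc1OC` gives -95%. Going by the values given here, the one measured step that bears on the change at hand, a number 124 percentage points higher from compound 1 to compound 2 (beyond the scatter), was large. Compound 4 `COc1ccc(C(=O)/C=C/c2cc(-c3cc(OC)c(OC)c(OC)c3)n[nH]2)cc1` differs from compound 2 by 4-methoxyphenyl in place of 3,4-dichlorophenyl on a carbonyl carbon. The group that enters carries one hydrogen-bond acceptor, and the other two measured compounds, which also carry groups other than 3,4-dichlorophenyl on the carbonyl carbon, both gave strongly negative values. A large step downward is therefore expected. Compound 4 is estimated at -50%, between -100% and 30%, an expected step of a number 90 percentage points lower from compound 2 to compound 4 (beyond the scatter).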

Compound 4, a percentage reported as activity, at one concentration (the size of the read-out at that concentration, not a potency): -93%
For compound 4 the middle estimate is 43 percentage points above the measured one; the range from low to high includes it.
By their numbers in this assay, from the lowest: compounds 3, 4 and 1 (each within the scatter of the next, the first and the last beyond it); then compound 2.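

In this assay, 4-methoxyphenyl on the carbonyl carbon in place of 3,4-dichlorophenyl gives a number 133 percentage points lower from compound 2 to compound 4 (beyond the scatter), so a second group at this position stands far from the 3,4-dichlorophenyl compound. Methoxy in place of amino on an aromatic carbon gives a number 9 percentage points lower from compound 1 to compound 4 (within the scatter), so 4-methoxyphenyl and 4-aminophenyl cannot be told apart here. Nothing given here explains these steps. From the compounds shown here alone, it remains open whether one chlorine, as in 4-chlorophenyl, reads like compound 2 or like compound 4. Going by these compounds, how a carboxylic acid on that aromatic ring would read also remains open.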